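The source may hold more compounds than are shown below. What is called first, only, known or untested is meant among the compounds shown, and "the series" means these compounds.

Measured so far in a functional assay on ECa-109 cells (Homo sapiens) for cytotoxicity, read by MTT assay, with a stated time of 48 h; a higher number here means a weaker inhibitor, a lower number a stronger inhibitor:
- Compound 1 `COc1cc(-n2c(-c3ccccc3)cn(C(C)=O)c2=O)cc(OC)c1OC`: > 50000 nM, a limit of the assay
- Compound 2 `COc1ccc(-c2cn(C(C)=O)c(=O)n2-c2cc(OC)c(OC)c(OC)c2)cc1`: > 50000 nM, a limit of the assay

Compound 2 therefore has no exact number in this assay, only a limit, and the same holds for everything measured so far: the limit of > 50000 nM in this assay, at which 2 of the 2 values shown sit.

Compound 3 `COc1ccc(-c2cn(C(C)=O)c(=O)n2-c2cc(OC)c(OC)c(OC)c2)cc1N` differs from compound 2 in one place: amino in place of hydrogen on an aromatic carbon. Amino takes the place of hydrogen on an aromatic carbon, turning 4-methoxyphenyl into 3-amino-4-methoxyphenyl.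

Going by the values given here, the only measured step is a step that the two limits leave unreadable from compound 1 to compound 2. It involves a different group and offers no size to carry over, so the data fix neither the direction nor the size of this new step. The expected step, an at least 5.0-fold lower number from compound 2 to compound 3 (0.69 log units; beyond the scatter), is a loose estimate leaning toward a stronger inhibitor, and another limit remains quite possible. For compound 3 the estimated value is 10000 nM, with an expected range of 300 nM to 50000 nM.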

Compound 3, half-maximal inhibitory concentration: > 50000 nM
Compound 3: a limit, no number; the forecaster's own chance of this, stated with the estimate: 45%; at least 5.0-fold (0.69 log units) between middle value and limit.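

Going by these compounds alone, compound 3 also ends at a limit of the assay, not a number, so no step among compound 1, compound 2 and compound 3 can be read. Left open is how strongly each acts in this assay, and whether they differ at all, because all three share one result: the limit of > 50000 nM in this assay, at which 3 of the 3 values shown sit.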